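Methyl on a Macrocycle Ring Carbon: Expected Half-Life

A few compounds are considered here, and "the series" means these few. Any claim that something is new, unique, unknown or untested is made for them only; others in the source may bear on it.

Measured in an ADME assay on microsomes from liver (Homo sapiens) for metabolic stability, read by LC-MS, using NADPH, with a stated time of 45 min; a higher number here means that the compound lasts longer, a lower number that the compound disappears faster:
- compound 1, `COc1cnc(O[C@@H]2C[C@H]3C(=O)N[C@]4(C(=O)NS(=O)(=O)C5CC5)C[C@H]4/C=C\CCCCC[C@H](NC(=O)OC(C)(C)C)C(=O)N3C2)c2cc(Cl)ccc12`: 0.107 h
- compound 2, `COc1cnc(O[C@@H]2C[C@H]3C(=O)N[C@]4(C(=O)NS(=O)(=O)C5CC5)C[C@H]4/C=C\CCCC[C@@H](C)[C@H](NC(=O)OC(C)(C)C)C(=O)N3C2)c2cc(Cl)ccc12`: 0.192 h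
- compound 3, `COc1cnc(O[C@@H]2C[C@H]3C(=O)N[C@]4(C(=O)NS(=O)(=O)C5CC5)C[C@H]4/C=C\CCCC[C@@H](C)[C@H](NC(=O)OC(C)(C)C(F)(F)F)C(=O)N3C2)c2ccccc12`: 0.31 h

One measured step, a 1.8-fold higher number from compound 1 to compound 2 (0.25 log units; within the scatter), came with the change (methyl in place of hydrogen on a saturated ring carbon). Compound 3 has a different core; how it differs from that of compound 1 is not broken down here. Compound 4, `COc1cnc(O[C@@H]2C[C@H]3C(=O)N[C@]4(C(=O)NS(=O)(=O)C5CC5)C[C@H]4/C=C\CC[C@@H](C)C[C@@H](C)[C@H](NC(=O)OC(C)(C)C(F)(F)F)C(=O)N3C2)c2ccccc12`, has not been measured; it differs from compound 3 by methyl in place of hydrogen on a saturated ring carbon. This is the same kind of change, at another spot on the ring: two ring bonds from the ring atom that bears a methyl group and three from the ring atom bearing the ((1-methyl-1-(trifluoromethyl)ethoxy)carbonyl)amino group, rather than next to the ring atom bearing the (tert-butoxycarbonyl)amino group. Because the earlier step of a 1.8-fold higher number from compound 1 to compound 2 (0.25 log units; within the scatter) stayed within the scatter, a step of similar modest size is expected here, a 1.4-fold higher number from compound 3 to compound 4 (0.13 log units; within the scatter). Compound 4 is thus estimated at 0.42 h in this assay. For compound 4 the expected range runs from 0.2 h to 0.9 h.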

Compound 4, half-life: 0.198 h
For compound 4 the middle estimate is 2.1-fold (0.33 log units) above the measured one; the measured number lies below the stated range.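

In this assay, methyl in place of hydrogen on a saturated ring carbon gave a 1.6-fold lower number from compound 3 to compound 4 (0.19 log units; within the scatter). Set beside the earlier step, this shows that the change cannot be carried from one core to another as a single number: the same change on two cores in this assay, a 1.8-fold higher number (0.25 log units; within the scatter) from compound 1 to compound 2 and a 1.6-fold lower number (0.19 log units; within the scatter) from compound 3 to compound 4, 2.8-fold (0.45 log units) apart, beyond the scatter of two such steps Each step alone stays within the scatter, and the methyl sits at a different spot on the ring in compound 4 than in compound 2, so the effect of the core and the effect of the spot cannot be told apart.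

The compounds shown leave open what the same methyl, at one and the same spot, would do on both cores. They also leave open whether an ethyl or a fluorine on this ring carbon would give a step of another size.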